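The source may report more compounds than this note shows. Statements on the series, on what has been measured and on what is new or still open speak of the compounds shown alone.

Measured so far in an ADME assay on a cell-free system (plasma, Homo sapiens) for protein binding; on this read-out lower numbers stand for a smaller free fraction and higher numbers for a larger free fraction:

- compound 1 `Cc1c(CF)nnc2sc(C(=O)NC3CN(c4ncc(C(F)(F)F)cn4)C3)c(N)c12`: 0.042
- compound 2 `COc1nnc2sc(C(=O)NC3CN(c4ncc(C(F)(F)F)cn4)C3)c(N)c2c1C`: 0.02

Of these two, compound 1 sits higher and compound 2 stands lowest, at 0.02. The next compound to be measured, compound 3 `Cc1nnc2sc(C(=O)NC3CN(c4ncc(C(F)(F)F)cn4)C3)c(N)c2c1C`, keeps the shared core and changes one group relative to compound 2: methyl in place of methoxy on an aromatic carbon.

Among the measured compounds shown here, only one measured step bears on this change. It is a 2.1-fold lower number from compound 1 to compound 2 (0.32 log units; beyond the scatter), which is modest and brought methoxy onto that same aromatic carbon, in place of fluoromethyl. Here the methoxy leaves again, so a modest step of about that size is expected in this assay, in the opposite direction, towards a higher number and a larger free fraction. For the measured compounds named here, this is only an indirect guide, as no measured compound carries methyl at this place. The expected step is a 1.9-fold higher number from compound 2 to compound 3 (0.28 log units; within the scatter). For compound 3 the estimated value is 0.038, with an expected range from 0.018 to 0.08.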

Compound 3, unbound fraction: 0.048
For compound 3 the middle estimate is 1.3-fold (0.10 log units) below the measured one; low and high end bracket the measured number.
By their numbers in this assay, from the lowest: compound 2; then compounds 1 and 3 (each within the scatter of the next).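

In this assay, the methoxy on this aromatic carbon now differs from two other groups rather than one: with methyl in its place the number rises (a 2.4-fold higher number from compound 2 to compound 3 (0.38 log units; beyond the scatter)), a step beyond the scatter that runs opposite to the earlier step onto methoxy from fluoromethyl. Removing the fluoro from the saturated chain carbon bound to the aromatic carbon gives a step within the scatter (a 1.1-fold higher number from compound 1 to compound 3 (0.06 log units; within the scatter)), so methyl and fluoromethyl cannot be told apart at this place on this read-out, and of the three compounds shown only the methoxy compound stands apart from the others. No measurement at hand says what lies behind this difference.

As far as these compounds go, the three compounds carry only methoxy, fluoromethyl and methyl at this place, so it remains open whether an amine, a hydroxyl group or a longer chain such as ethyl would fall with methoxy or with the other two. From the compounds shown here alone, it is also open whether the methoxy step would recur with a different group in place of the neighbouring methyl or on a different core.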